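Trading a Methyl for Hydrogen on Selenium

The compounds below may be only part of what the source reports. "The series", "measured", "known", "first", "only" and "open" are said of these compounds alone.

Compound 1 `COc1ccc(CNc2nc([Se]C)nc3ccccc23)cc1` was tested in an ADME assay on BEAS-2B cells (Homo sapiens) for cytotoxicity, read by MTT assay, with a stated time of 72 h; a lower number here means a stronger inhibitor of growth, a higher number a weaker inhibitor of growth. Compound 1 reached only the limit of the assay, > 100000 nM, so for compound 1 there is no number, only (the limit of > 100000 nM in this assay, at which 1 of the 3 values shown sits). Two related compounds do give numbers. In this assay compound 2 `C[Se]c1nc(N)c2ccccc2n1` gives 54600 nM, and compound 3 `CSc1ccc(CNc2nc(SC)nc3ncccc23)cc1` gives 3770 nM. Among the measured compounds shown here, none of these three compounds differs from another in just one place, so no single step between measured compounds can be read off from them.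

Compound 4 `COc1ccc(CNc2nc([SeH])nc3ccccc23)cc1` differs from compound 1 by hydrogen in place of methyl on a selenium. For the measured compounds named here, no measured step resembles this change, so its size and direction can only be guessed. A small shift toward stronger growth inhibition is expected, with the step from compound 1 to compound 4 estimated as an at least 1.4-fold lower number from compound 1 to compound 4 (0.15 log units; that floor lies within the scatter). For compound 4 the value in this assay is estimated at 70000 nM, expected to lie between 15000 nM and 200000 nM.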

Compound 4, concentration for total growth inhibition: > 100000 nM
Compound 4: only a limit was reported; the forecaster's own chance of this, stated with the estimate: 45%; middle value at least 1.4-fold (0.15 log units) from the limit.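

No new step can be read between compound 1 and compound 4, because in this assay both compounds stop at a limit rather than giving a number: the limit of > 100000 nM in this assay, at which 2 of the 4 values shown sit. The compounds shown leave open how large the effect of hydrogen in place of methyl on a selenium is, and in which direction it runs.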